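Swapping a Butyl Chain for Cyclopentyl on Two Cores

A few compounds are considered here, and "the series" means these few. Any claim that something is new, unique, unknown or untested is made for them only; others in the source may bear on it.

Compound 1 `CCCCn1cnc2c(NCc3ccc(C(=O)Nc4ccccc4N)cc3)nc(Cl)nc21` and compound 2 `Nc1ccccc1NC(=O)c1ccc(CNc2nc(Cl)nc3c2ncn3C2CCCC2)cc1` share one core and differ in a single place, where the change is cyclopentyl in place of butyl on an aromatic nitrogen. In a functional assay on HCT-116 cells (Homo sapiens) for antiproliferative activity, read by CCK-8 assay, with a stated time of 72 h, tested at 8 uM (a lower number here means a weaker effect, a higher number a stronger effect of the compound at the concentration tested), compound 1 gives 40.9%, while compound 2 gives 80.6%, so the step of a number 39.7 percentage points higher from compound 1 to compound 2 (beyond the scatter) is large and clearly beyond the scatter. Compound 3 `CCCCn1cnc2c(Nc3ccccc3)nc(NCOCc3ccc(/C=C/C(=O)Nc4ccccc4N)cc3)nc21` rests on a different core, and how the two cores differ is not broken down here. In this assay compound 3 gives 51.9%, which stands second among the three measured compounds, beyond the scatter from each of the other two. Compound 4 `Nc1ccccc1NC(=O)/C=C/c1ccc(COCNc2nc(Nc3ccccc3)c3ncn(C4CCCC4)c3n2)cc1` carries the change (cyclopentyl in place of butyl on an aromatic nitrogen), described in exactly the same words and at the same kind of place, so it is the same change made on the second core. Because the earlier step of a number 39.7 percentage points higher from compound 1 to compound 2 (beyond the scatter) was large, a rise is expected for compound 4 as well, though the different core means its size need not repeat. The expected step is estimated at a number 22.1 percentage points higher from compound 3 to compound 4 (beyond the scatter). Compound 4 is therefore expected to give about 74% in this assay, most likely between 56% and 90%.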

Compound 4, a percentage reported as inhibition, at one concentration (the size of the read-out at that concentration, not a potency): 17.3%
The estimate for compound 4 lay 56.7 percentage points above the measured number; measured number outside the range, below it.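

On the second core, the swap of butyl for cyclopentyl went the opposite way in this assay, with a number 34.6 percentage points lower from compound 3 to compound 4 (beyond the scatter), so the rise seen on the first core did not carry over. The two steps disagree in direction, and the gap between them is real: the same change on two cores in this assay, a number 39.7 percentage points higher (beyond the scatter) from compound 1 to compound 2 and a number 34.6 percentage points lower (beyond the scatter) from compound 3 to compound 4, 74.3 percentage points apart, beyond the scatter of two such steps. For these four compounds, this shows that the outcome of the change depends on the core that carries it, but with one pair per core it does not show which difference between the cores is responsible, or how the change would behave on any further core.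

The compounds shown leave open whether the reversal is particular to cyclopentyl or whether another group on that aromatic nitrogen, such as a cyclohexyl ring or a longer chain, would also split the two cores. They also leave open whether the same reversal would hold at other concentrations, since each number here is a read-out at one concentration and not a potency.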